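The source may hold more compounds than are shown below. What is called first, only, known or untested is meant among the compounds shown, and "the series" means these compounds.

Measured so far:
Compound 1 `Cc1ccccc1Nc1ncnn1-c1cccc(Cl)c1Cl` gives 240 nM in a functional assay for antagonist activity at P2X purinoceptor 7 (Rattus norvegicus), read by FLIPR and calcium flux; a lower number here means a stronger inhibitor, a higher number a weaker inhibitor.
Compound 2 `Clc1cccc(-n2ncnc2NCc2cccnc2)c1Cl` gives 1320 nM in this assay.

Of these two numbers compound 2 carries the higher one and is therefore the weaker inhibitor of the pair; the step of a 5.5-fold higher number from compound 1 to compound 2 (0.74 log units; beyond the scatter) arose from swapping the whole group on the ring nitrogen. Compound 3 `Clc1cccc(-n2ncnc2NCc2cccnc2-c2ccsc2)c1Cl` differs from compound 2 by thiophen-3-yl in place of hydrogen on an aromatic carbon. Among the compounds with values here, no measured step adds a ring at this place, so the single known step, which came from a swap elsewhere, bears on it only indirectly: it shows that the group on this side of the core can shift the number by a modest amount in either direction. Nothing measured matches the present change, so the expectation stays cautious. Compound 3 is expected to show a modest improvement, a step of a 1.7-fold lower number from compound 2 to compound 3 (0.22 log units; within the scatter). Compound 3 is therefore estimated at 800 nM, with a range from 250 nM to 2500 nM.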

Compound 3, half-maximal inhibitory concentration: 138 nM
Estimate against measurement, compound 3: 5.8-fold (0.76 log units) above; measured number below the stated range.
By their numbers in this assay, from the lowest: compounds 3 and 1 (each within the scatter of the next); then compound 2.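

In this assay, thiophen-3-yl on an aromatic carbon of the six-membered aromatic ring with 1 nitrogen, next to the ring nitrogen, gives a 9.6-fold lower number from compound 2 to compound 3 (0.98 log units; beyond the scatter). Within the data shown here, this is the first sign that this carbon, which bears only hydrogen in compound 2, can carry a whole ring, and that here the added ring gives a stronger inhibitor rather than a weaker one. Nothing shown here offers a reason for this gain.

A single ring at a single place cannot show whether the sulfur matters or whether other groups on this carbon, such as a phenyl ring, a methyl or an amine, would move the number as far. On these data alone, it also remains open whether the gain would carry over to a compound with the 2-methylphenyl group of compound 1.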